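Amino in Place of Nitro: Compound 3 to Compound 4

A few compounds are considered here, and "the series" means these few. Any claim that something is new, unique, unknown or untested is made for them only; others in the source may bear on it.

Of the compounds shown here, three on a shared core have been measured. Compound 1 `C/C=C(\CC)Oc1cc(C)nc(Oc2c(C)cc(C)cc2C)c1C` gives 75% in a functional assay on the whole organism for displacement of a labelled ligand, with Rattus norvegicus as the target, at a dose of 3.2 mg/kg by the subcutaneous route; a lower number here means less inhibition, a higher number more inhibition at the dose given (going by the name of the read-out). Compound 2 `CCc1c(OC(CC)CC)cc(C)nc1Oc1c(C)cc(C)cc1C` gives 57%, and compound 3 `CCC(CC)Oc1cc(C)nc(Oc2c(C)cc(C)cc2C)c1[N+](=O)[O-]` gives 59%, the second highest of the three, closest to compound 2 and furthest from compound 1. For the measured compounds named here, the only measured step is a number 2 percentage points higher from compound 2 to compound 3 (within the scatter), nitro in place of ethyl on an aromatic carbon. Compound 4 `CCC(CC)Oc1cc(C)nc(Oc2c(C)cc(C)cc2C)c1N` differs from compound 3 by amino in place of nitro on an aromatic carbon. Going by the values given here, no measured step involves an amino group, so the expectation leans on the small step from compound 2 to compound 3 alone. Compound 4 is therefore expected to give about 57%, in a range of 38% to 75%. The expected step is a number 2 percentage points lower from compound 3 to compound 4 (within the scatter), nothing beyond the scatter.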

Compound 4, a percentage reported as inhibition, in the whole organism at one dose (the size of the read-out at that dose, not a potency): 78%
Beside the measured number, compound 4's estimate is 21 percentage points below it; measured number above the stated range.
By their numbers in this assay, from the lowest: compounds 2 and 3 (each within the scatter of the next); then compounds 1 and 4 (each within the scatter of the next).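

At the aromatic carbon ortho to the (pentan-3-yl)oxy group, amino in place of nitro gives a number 19 percentage points higher from compound 3 to compound 4 (beyond the scatter) in this assay and amino in place of ethyl gives a number 21 percentage points higher from compound 2 to compound 4 (beyond the scatter) on the same read-out. The earlier swap at this carbon gave only a number 2 percentage points higher from compound 2 to compound 3 (within the scatter) and so did not show that a change here could move the number beyond the scatter. Nothing at hand accounts for the gain with amino.

Still open, from the compounds shown here alone, is whether a methylamino group or a hydroxyl group at this carbon would keep the number near that of compound 4, and whether the gain holds at other doses.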